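A few compounds are considered here, and "the series" means these few. Any claim that something is new, unique, unknown or untested is made for them only; others in the source may bear on it.

Compound 1 `Cc1csc(N/N=C/c2ccccc2)n1` gives 1.32 nM in an assay on mitochondria for inhibition of Amine oxidase [flavin-containing] B (Bos taurus); a lower number here means a stronger inhibitor, a higher number a weaker inhibitor; compound 2 `Cc1csc(N/N=C/c2ccc(Cl)cc2)n1` gives 9.12 nM.

Among these two numbers compound 2 stands highest, and its nearest neighbour, compound 1, lies well below it. Compound 3 `Cc1csc(N/N=C/c2ccc(Cl)cc2Cl)n1` differs from compound 2 by chloro in place of hydrogen on an aromatic carbon. For the measured compounds named here, the one measured step that bears on this change, a 6.9-fold higher number from compound 1 to compound 2 (0.84 log units; beyond the scatter), also put a chloro in place of hydrogen and weakened inhibition clearly. Adding another chloro is therefore expected to weaken inhibition again, by a step of similar or somewhat smaller size, a 2.7-fold higher number from compound 2 to compound 3 (0.44 log units; beyond the scatter). For compound 3 the estimated value is 25 nM, within a range from 7 nM to 90 nM.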

Compound 3, inhibition constant: 17 nM
Beside the measured number, compound 3's estimate is 1.5-fold (0.17 log units) above it, and the stated range covers the measured number.
By their numbers in this assay, from the lowest: compound 1; then compounds 2 and 3 (each within the scatter of the next).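

Placed on the aromatic ring ortho to a group of 9 heavy atoms and meta to the existing chloro, the second chloro gives a 1.9-fold higher number from compound 2 to compound 3 (0.27 log units; within the scatter) in this assay. So, unlike the first chloro, with a 6.9-fold higher number from compound 1 to compound 2 (0.84 log units; beyond the scatter), this one brings no change that can be told from the scatter. No available measurement explains this difference between the two steps. Going by these compounds, what a chloro at this place does without the other chloro remains open. So does whether a methoxy group or an amine there would leave the number just as unchanged.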